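Removing Both Halogens from the Sulfonyl Aryl Group

The source may hold more compounds than are shown below. What is called first, only, known or untested is meant among the compounds shown, and "the series" means these compounds.

Measured so far, in an assay on isolated protein for displacement of a labelled ligand from metabotropic glutamate receptor 5 (Homo sapiens), with a stated time of 60 min, tested at 1 uM; a higher number here means more inhibition at the concentration tested (going by the name of the read-out), a lower number less inhibition:
- Compound 1, `CC1CCN(c2c(S(=O)(=O)c3ccc(Cl)cc3)cnc3c(F)cccc23)CC1`, gives 85%.
- Compound 2, `CC1CCN(c2c(S(=O)(=O)c3ccc(F)c(Cl)c3)cnc3c(F)cccc23)CC1`, gives 95%.

Among the compounds with values here, compound 2 has the highest of the two numbers, but its only neighbour is compound 1, and the step of a number 10 percentage points higher from compound 1 to compound 2 (within the scatter) lies within the scatter, so the two compounds cannot be told apart on these data.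

Compound 3, `CC1CCN(c2c(S(=O)(=O)c3ccccc3)cnc3c(F)cccc23)CC1`, has not yet been measured. Its change is phenyl in place of 3-chloro-4-fluorophenyl on a sulfonyl sulfur. Within the data shown here, the one measured step bears on it only loosely: it swapped a 4-chlorophenyl for a 3-chloro-4-fluorophenyl and stayed within the scatter. Going to plain phenyl removes both halogens at once, a larger change, for which no step has been measured. Compound 3 is therefore estimated at 78% in this assay, within a range from 55% to 95%. The expected step is a number 17 percentage points lower from compound 2 to compound 3 (beyond the scatter), a modest drop that may still fall inside the scatter.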

Compound 3, a percentage reported as inhibition, at one concentration (the size of the read-out at that concentration, not a potency): 13%
Estimate against measurement, compound 3: 65 percentage points above; measured number below the stated range.
By their numbers in this assay, from the lowest: compound 3; then compounds 1 and 2 (each within the scatter of the next).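

In this assay, the halogens on the aryl group on the sulfonyl sulfur prove to matter far more than the earlier swap between two halogenated rings could show (a number 82 percentage points lower from compound 2 to compound 3 (beyond the scatter)). Removing the single chloro of the 4-chlorophenyl group has a similarly large effect (a number 72 percentage points lower from compound 1 to compound 3 (beyond the scatter)), so one halogen is enough to separate compound 1 from compound 3. Among these three compounds, the read-out stays high with either halogen pattern and collapses only on plain phenyl.

Still open, going by these compounds, is which halogen in compound 2 matters, and whether a methyl, methoxy or nitrile on the phenyl could replace it. Nothing presented here explains the loss, so its cause remains unknown.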